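Compound 4: a carboxyphenoxymethyl ether tested as an mGlu3 modulator

A few compounds are considered here, and "the series" means these few. Any claim that something is new, unique, unknown or untested is made for them only; others in the source may bear on it.

Measured compounds:
compound 1 `CCC(=O)c1ccc(OCCCCOc2ccc(F)c(C(=O)O)c2)c(C)c1O`: "not determined" (no result reported)
compound 2 `Cc1c(OCCCCOc2ccc(F)c(C(=O)O)c2)ccc(C(=O)CC2CCCC2)c1O`: 2490 nM
compound 3 `COc1ccc(C(=O)O)cc1OCCCCOc1ccc(C(=O)CC(C)C)c(O)c1C`: 737 nM

In an assay on HEK293 cells for positive allosteric modulation of metabotropic glutamate receptor 3 (Rattus norvegicus), read by thallium flux, with a stated time of 2.5 min (a lower number here means that less compound is needed, a higher number that more compound is needed for the effect), compound 2 gives 2490 nM, the higher of the two numbers reported; compound 3 gives 737 nM, lower by a margin beyond the scatter. Compound 1 has no result in this assay.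

Compound 4 `Cc1c(OCCCCOCOc2ccc(C(=O)O)cc2)ccc(C(=O)CC2CCCC2)c1O` differs from compound 2 in one place: (4-carboxyphenoxy)methyl in place of 3-carboxy-4-fluorophenyl on an oxygen on a saturated carbon. Among the measured compounds shown here, no measured pair shows this kind of change, so the direction is uncertain. Given that compound 2 already stands at 2490 nM, compound 4 is expected to land near it or somewhat higher, with a step of a 1.4-fold higher number from compound 2 to compound 4 (0.15 log units; within the scatter) expected. The estimate for compound 4 is 3500 nM, within 1200 nM to 10000 nM.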

Compound 4, half-maximal effective concentration: 1910 nM
Compound 4: the middle estimate sits 1.8-fold (0.26 log units) above what was measured; the range from low to high includes it.
By their numbers in this assay, from the lowest: compound 3; then compounds 4 and 2 (each within the scatter of the next).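

Replacing 3-carboxy-4-fluorophenyl with (4-carboxyphenoxy)methyl on this oxygen gives a 1.3-fold lower number from compound 2 to compound 4 (0.12 log units; within the scatter), so this position tolerates the exchange of one carboxylic acid-bearing end group for another with no change beyond the scatter. The swap removes the fluorine and adds an oxygen and a methylene link at once, and this single pair cannot separate those parts. No measurement shown here bears on why the number holds. Still open, from the compounds shown here alone, is whether a methyl ester or a tetrazole could stand in place of the carboxylic acid on this end group.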